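A Methoxyphenyl Swap in a Weakly Cytotoxic Series

This account rests on a few compounds, and the source may have more. Where it says the series, first, only, none or still open, it means among the compounds named here.

Three analogues share one core and differ only in the methylphenyl bound to a nitrogen on an aromatic ring. Compound 1 `Cc1ccccc1Nc1nc(C)c(C(=O)/C=C/c2ccccc2Cl)s1` was tested in a functional assay on BGC-823 cells (Homo sapiens) for cytotoxicity, read by MTT assay (on this read-out higher numbers stand for weaker inhibition and lower numbers for stronger inhibition), and for compound 1 the result is a limit of the assay, > 25000 nM. Compound 2 `Cc1cccc(Nc2nc(C)c(C(=O)/C=C/c3ccccc3Cl)s2)c1` gives 24200 nM in this assay. For compound 3 `Cc1ccc(Nc2nc(C)c(C(=O)/C=C/c3ccccc3Cl)s2)cc1` the reading in this assay is again a limit, > 25000 nM. The step of an at least 1.0-fold lower number from compound 1 to compound 2 (0.01 log units; that floor lies within the scatter) and the step of an at least 1.0-fold higher number from compound 2 to compound 3 (0.01 log units; that floor lies within the scatter) lie within the scatter, and the step that the two limits leave unreadable from compound 1 to compound 3 cannot be read at all. Two of the three values sit at the limit of > 25000 nM in this assay, at which 2 of the 3 values shown sit. Compound 4 `COc1cccc(/C=C/C(=O)c2sc(Nc3ccc(C)cc3)nc2C)c1` carries the change (3-methoxyphenyl in place of 2-chlorophenyl on a double-bonded chain carbon bound to a double-bonded chain carbon). Among the compounds with values here, no measured step touches that part of the molecule, so the three measured compounds give no guide to direction, and the only anchor is that every reading so far stands at or close to the limit. The step that the limit leaves unreadable from compound 3 to compound 4 is thus an expectation with wide uncertainty. Compound 4 is expected to give roughly 30000 nM, between 8000 nM and 100000 nM, in this assay, most likely reported once more as a limit.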

Compound 4, half-maximal inhibitory concentration: > 25000 nM
Compound 4: no number, only a limit; the forecaster's own chance of this, stated with the estimate: 65%; the middle value lies beyond the limit too.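

Compound 3 and compound 4 both give a limit rather than a number, and the step between them cannot be read: the limit of > 25000 nM in this assay, at which 3 of the 4 values shown sit.

The compounds shown leave open whether 3-methoxyphenyl in place of 2-chlorophenyl changes the reading at all.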